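The source may hold more compounds than are shown below. What is called first, only, known or untested is meant among the compounds shown, and "the series" means these compounds.

Among the compounds with values here, the three compounds measured so far share a biaryl core and are compared in a functional assay on cells for agonist activity at Free fatty acid receptor 1 (Homo sapiens), read by calcium flux; a higher number here means that more compound is needed for the effect, a lower number that less compound is needed. Compound 1, `Cc1cccc(C)c1-c1cccc(COc2ccc(CCC(=O)O)cc2)c1`, gives 8 nM in this assay. Compound 2, `Cc1cccc(C)c1-c1cccc(COc2ccc(CC3SC(=O)NC3=O)s2)c1`, gives 82 nM. Compound 3, `Cc1cccc(C)c1-c1cccc(OCc2cn(CCC(=O)O)nn2)c1`, gives 14700 nM. Among these three numbers compound 2 stands second highest: its nearest neighbour is compound 1, whose number is lower by a margin beyond the scatter, and its furthest is compound 3, whose number is higher by a much wider margin, also beyond the scatter.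

The unmeasured compound 4, `CC#CC(CC(=O)O)c1ccc(OCc2cccc(-c3c(C)cccc3C)c2)s1`, is compared with compound 2. The difference between the two is 1-(carboxymethyl)but-2-yn-1-yl in place of (2,4-dioxo-1,3-thiazolidin-5-yl)methyl on an aromatic carbon. Both groups carry one hydrogen-bond donor; the group that enters has no ring and fewer hydrogen-bond acceptors, and it places a carboxylic acid on the same side of the core where compound 1 also carries its acid.

Within the data shown here, no step between measured compounds isolates this change, so the expectation rests on the numbers alone. Since compound 1 with its acid gives 8 nM while compound 2 gives 82 nM, the step is expected to run downward, beyond the scatter, as a 5.5-fold lower number from compound 2 to compound 4 (0.74 log units; beyond the scatter). Compound 4 is therefore estimated to give 15 nM in this assay, within a range from 4 nM to 60 nM.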

Compound 4, half-maximal effective concentration: 210 nM
For compound 4 the middle estimate is 14-fold (1.15 log units) below the measured one; the measured number lies above the stated range.
By their numbers in this assay, from the lowest: compound 1; then compound 2; then compound 4; then compound 3.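

In this assay, within the data shown here, putting 1-(carboxymethyl)but-2-yn-1-yl in place of (2,4-dioxo-1,3-thiazolidin-5-yl)methyl on the aromatic carbon next to the ring sulfur gives a 2.6-fold higher number from compound 2 to compound 4 (0.41 log units; beyond the scatter) as the first step that isolates a change at this position. The step is modest but beyond the scatter, and it shows that at this position the open-chain group with its carboxylic acid, which has no ring and fewer hydrogen-bond acceptors, gives a higher number than the ring group of the same heavy-atom count. Nothing given here accounts for the direction or size of this step.

The compounds shown leave open which part of the entering group carries the step, as a plain 2-carboxyethyl chain, with neither the branch nor the triple bond, would separate the carboxylic acid from the but-2-yn-1-yl portion at this position. They also leave open whether the same exchange would run in the same direction on the core of compound 1, and how a tetrazole would compare with both groups on this aromatic carbon.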